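Swapping cyclopentyl for cyclohexyl on the sulfur

The source may report more compounds than this note shows. Statements on the series, on what has been measured and on what is new or still open speak of the compounds shown alone.

Measured in a functional assay on MT4 cells (Homo sapiens) for cytotoxicity (a lower number here means that less compound is tolerated, a higher number that more compound is tolerated), so far:
Compound 1 `CC(C)Sc1nc(O)cc(C(C)c2cccc3ccccc23)n1` gives 119000 nM (a number)
Compound 2 `CC(c1cc(O)nc(SC2CCCC2)n1)c1cccc2ccccc12` gives 93000 nM (a number)
Compound 3 `CCC(c1cc(O)nc(SC2CCCC2)n1)c1cccc2ccccc12` gives > 200000 nM (a limit, not a number)

Going by the values given here, compound 2 lies within the scatter of compound 1, and these are the only two exact numbers so far. Compound 4 `CC(c1cc(O)nc(SC2CCCCC2)n1)c1cccc2ccccc12` carries cyclohexyl in place of cyclopentyl on a sulfur and is otherwise the same as compound 2.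

The closest guide is a change to the same group on the same sulfur, and that step was small: a 1.3-fold lower number from compound 1 to compound 2 (0.11 log units; within the scatter) stayed within the scatter. The other measured step, an at least 2.1-fold higher number from compound 2 to compound 3 (0.33 log units; beyond the scatter), was made on a saturated chain carbon instead, so it says less about this swap.

The expected step is a 1.0-fold higher number from compound 2 to compound 4 (0.01 log units; within the scatter) and no shift beyond the scatter is anticipated. Compound 4 is expected near 95000 nM in this assay with an estimated range from 45000 nM to 190000 nM around that middle.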

Compound 4, half-maximal cytotoxic concentration: 45000 nM
Estimate against measurement, compound 4: 2.1-fold (0.32 log units) above; the measured number falls inside the stated range.
By their numbers in this assay, from the lowest: compound 4; then compounds 2 and 1 (each within the scatter of the next). At a limit, above all of these: compound 3.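

In this assay, the group on this sulfur can shift the number after all: the earlier change here was small, a 1.3-fold lower number from compound 1 to compound 2 (0.11 log units; within the scatter), but the new one is larger, a 2.1-fold lower number from compound 2 to compound 4 (0.32 log units; beyond the scatter). The comparison with the isopropyl compound agrees, with a 2.6-fold lower number from compound 1 to compound 4 (0.42 log units; beyond the scatter), so among the three groups shown on this sulfur, cyclohexyl is the one that goes with less compound being tolerated. Nothing shown explains why cyclohexyl differs from cyclopentyl and isopropyl here.

Going by these compounds, whether a cycloheptyl ring would lower the number further, or a piperidine ring holding an amine would behave differently, stays open. Compound 3 gives > 200000 nM as a limit of the assay and not a number, and what the same chain change would do with cyclohexyl on the sulfur is also unknown.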